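The source may report more compounds than this note shows. Statements on the series, on what has been measured and on what is new or still open speak of the compounds shown alone.

Measured so far:
compound 1, `Cc1cccc(N2CCN(CCCNc3nc(NCc4ccco4)c4ccccc4n3)CC2)c1C`: 840 nM
compound 2, `Fc1ccc2nc(NCCCCN3CCN(c4cccc(Cl)c4Cl)CC3)nc(NCc3ccco3)c2c1`: 390 nM
compound 3, `Cc1cccc(N2CCN(CCCNc3nc(NCc4ccco4)c4cc(F)ccc4n3)CC2)c1C`: 1050 nM

All three were tested in a functional assay on HT-29 cells (Homo sapiens) for cytotoxicity, read by MTT assay, with a stated time of 2 days; on this read-out higher numbers stand for weaker inhibition and lower numbers for stronger inhibition. In this assay compound 2 gives the lowest number of the three, and its steps to both other compounds lie beyond the usual scatter, so it is the most potent compound measured here. Compound 1 and compound 3 lie within the scatter of each other, so no order can be read between them.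

One structural change is seen twice among these compounds. From compound 3 to compound 1 the change is hydrogen in place of fluoro on an aromatic carbon, and it made a step of a 1.3-fold lower number from compound 3 to compound 1 (0.10 log units; within the scatter). Compound 4, `Clc1cccc(N2CCN(CCCCNc3nc(NCc4ccco4)c4ccccc4n3)CC2)c1Cl`, is not yet measured; it arises from compound 2 by hydrogen in place of fluoro on an aromatic carbon, the same change at the same kind of place. How the core of compound 2 differs from that of compound 3 is not broken down here.

Because the step of a 1.3-fold lower number from compound 3 to compound 1 (0.10 log units; within the scatter) lies within the scatter, only a small step of about a 1.3-fold lower number from compound 2 to compound 4 (0.10 log units; within the scatter) is expected here. Compound 4 is therefore estimated at 310 nM, with a likely range from 150 nM to 650 nM.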

Compound 4, half-maximal inhibitory concentration: 3370 nM
Compound 4: middle estimate off by 11-fold (1.04 log units), on the low side, outside the stated range (above it).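

Replacing fluoro with hydrogen on the aromatic carbon of compound 2 gave an 8.6-fold higher number from compound 2 to compound 4 (0.94 log units; beyond the scatter) in this assay, so on this core, keeping the fluoro goes with clearly stronger inhibition. The size of this step therefore did not carry over from one core to the other: the same change on two cores in this assay, a 1.3-fold lower number (0.10 log units; within the scatter) from compound 3 to compound 1 and an 8.6-fold higher number (0.94 log units; beyond the scatter) from compound 2 to compound 4, 11-fold (1.03 log units) apart, beyond the scatter of two such steps This shows that a result for this change on one core is a poor guide to its result on the other, but it does not show which feature of the cores makes the difference, as the core of compound 2 and that of compound 3 differ in more than one place.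

Which of those differences matters stays open, and a pair of compounds differing only in the linking chain, or only in the groups on the outer benzene ring, would be needed to separate them. Going by these compounds, it also remains open whether a methoxy group or a nitrile on the same aromatic carbon would behave like the fluoro on each core.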